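The source may hold more compounds than are shown below. What is called first, only, known or untested is meant among the compounds shown, and "the series" means these compounds.

Series notes. Compound 1 `CC(CC(=O)/N=C(\N)NCCCn1ccnc1)c1ccccc1` is the reference for this step. Among the measured compounds shown here, in an assay on ileum for antagonist activity at histamine H1 receptor (Cavia porcellus), with a stated time of 15 min (a higher number here means weaker binding, a lower number tighter binding), compound 1 gives 1120 nM, the lowest of the three numbers so far. Compound 2 `N/C(=N\C(=O)CC(c1ccccc1)c1ccccc1)NCCCn1ccnc1` carries phenyl in place of methyl and gives 2340 nM in this assay; the step of a 2.1-fold higher number from compound 1 to compound 2 (0.32 log units; beyond the scatter) is modest but beyond the scatter. Compound 3 `N/C(=N\C(=O)CC(c1ccccc1)c1ccccc1)NCCCc1cn[nH]c1` differs from compound 2 only in the ring at the chain end; in this assay compound 3 gives 2570 nM, and the step of a 1.1-fold higher number from compound 2 to compound 3 (0.04 log units; within the scatter) lies within the scatter.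

Compound 4 `CC(CC(=O)/N=C(\N)NCCCc1ncn[nH]1)c1ccccc1` is not yet measured. Its change from compound 1 is 1H-1,2,4-triazol-5-yl in place of 1H-imidazol-1-yl on a saturated chain carbon, three bonds along the chain from an amine nitrogen. The step that bears on it is the ring exchange at the same place, which was flat, because a 1.1-fold higher number from compound 2 to compound 3 (0.04 log units; within the scatter) stayed within the scatter; the phenyl step does not bear on it. No step beyond the scatter is therefore expected for compound 4 in this assay, and the expected step is a 1.2-fold higher number from compound 1 to compound 4 (0.06 log units; within the scatter). Compound 4 is estimated at 1300 nM in this assay, within a range of 500 nM to 3500 nM.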

Compound 4, dissociation constant: 1480 nM
The estimate for compound 4 lay 1.1-fold (0.06 log units) below the measured number; the range from low to high includes it.
By their numbers in this assay, from the lowest: compounds 1, 4, 2 and 3 (each within the scatter of the next, the first and the last beyond it).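

In this assay, the exchange of 1H-imidazol-1-yl for 1H-1,2,4-triazol-5-yl, on a saturated chain carbon three bonds along the chain from an amine nitrogen, gives a 1.3-fold higher number from compound 1 to compound 4 (0.12 log units; within the scatter). The flat result of the earlier ring exchange, a 1.1-fold higher number from compound 2 to compound 3 (0.04 log units; within the scatter), therefore also holds with methyl in place of phenyl on the chain carbon, and this position has now tolerated two different ring exchanges on two different side chains, while the step from 0 to 1 hydrogen-bond donor and from 2 to 3 ring nitrogens in the group leaves the number within the scatter. Nothing available explains this tolerance.

Still open, from the compounds shown here alone, is whether the chain end requires an aromatic ring at all, which an amine or a carboxylic acid there would test. Going by these compounds, the effect of a longer chain between the amine nitrogen and the ring also remains unknown.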